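Swapping a Ring and Adding a Carbon: Half-Life Outlook

The source may report more compounds than this note shows. Statements on the series, on what has been measured and on what is new or still open speak of the compounds shown alone.

Compound 1, `Cc1cc(C(/C=C2\OC(=O)NC2=O)C(C)C)c(=O)[nH]c1-c1ccc2cccc(F)c2c1`, reaches the limit of > 3 h in an ADME assay on microsomes from liver (Homo sapiens) for metabolic stability; a lower number here means that the compound disappears faster, a higher number that the compound lasts longer.
Compound 2, `CC(C)[C@@H](c1ccc(-c2ccc3cccc(F)c3c2)[nH]c1=O)[C@H]1OC(=O)NC1=O`, also reaches the limit of > 3 h in this assay.
Compound 3, `CC(C)C(c1ccc(-c2ccc3cccc(F)c3c2)[nH]c1=O)C1SC(=O)NC1=O`, gives 1.87 h in this assay.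

Compound 2 therefore stands at the top of what the measurement can report: its value is a limit rather than a number, and it shares that position with compound 1 (the limit of > 3 h in this assay, at which 2 of the 3 values shown sit). Only compound 3 returned an actual figure.

Compound 4, `CC(C)[C@H](C[C@H]1SC(=O)NC1=O)c1ccc(-c2ccc3cccc(F)c3c2)[nH]c1=O`, has not yet been measured in this assay. Relative to compound 2 it changes in one place: (2,4-dioxo-1,3-thiazolidin-5-yl)methyl in place of 2,4-dioxo-1,3-oxazolidin-5-yl on a saturated chain carbon bound to an aromatic carbon and a saturated chain carbon. Among the measured compounds shown here, no pair of measured compounds differing in a single place is available, so no measured step can anchor the change.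

The step from compound 2 to compound 4 in this assay is expected to be a modest shortening, roughly an at least 1.3-fold lower number from compound 2 to compound 4 (0.13 log units; that floor lies within the scatter), because compound 3, which also carries the sulfur-containing ring, gives 1.87 h rather than a limit. Compound 4 is estimated at 2.2 h, within 1.1 h to 4 h.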

Compound 4, half-life: 0.67 h
For compound 4 the middle estimate is 3.3-fold (0.52 log units) above the measured one, and the stated range ends above it.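

The value of compound 2, > 3 h in this assay, is a limit of the assay and not a number. Even so, the step can be read, and it shows that this place is sensitive: putting (2,4-dioxo-1,3-thiazolidin-5-yl)methyl in place of 2,4-dioxo-1,3-oxazolidin-5-yl on the saturated chain carbon gives an at least 4.4-fold lower number from compound 2 to compound 4 (0.65 log units; beyond the scatter). The earlier values offered no step at all, so this is the only measured link shown between a change at this place and a shorter half-life.

This one step alters the ring and the chain length together, so it cannot say which of the two accounts for the drop. The compounds shown leave open how (2,4-dioxo-1,3-oxazolidin-5-yl)methyl, with the oxygen-containing ring on the same methyl link, or a longer chain would behave at this place.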